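This account rests on a few compounds, and the source may have more. Where it says the series, first, only, none or still open, it means among the compounds named here.

Compound 2 `O=C(C(Nc1ccccc1F)c1ccc(C(F)(F)F)cc1)N1CCCC1c1ccccn1` gives 25 nM in an assay on HEK293 cells for antagonist activity at transient receptor potential M8 protein (Canis lupus familiaris), read by fluorescence and calcium flux, with a stated time of 5 min (a lower number here means a stronger inhibitor, a higher number a weaker inhibitor), the higher of the two numbers recorded; compound 1 `O=C(C(Nc1ccccc1F)c1ccc(C(F)(F)F)cc1)N1CCCC1c1ccccc1Cl` gives 11 nM. Among the compounds with values here, the one measured step, a 2.3-fold higher number from compound 1 to compound 2 (0.36 log units; beyond the scatter), came from a change at the same saturated ring carbon. Compound 3 `O=C(C(Nc1ccccc1F)c1ccc(C(F)(F)F)cc1)N1CCCC1c1cccnc1` differs from compound 2 by pyridin-3-yl in place of pyridin-2-yl on a saturated ring carbon. Within the data shown here, no measured step moves the ring nitrogen within a pyridinyl group, so that prior step offers only a loose guide to size. For compound 3 the expected step is a 1.2-fold higher number from compound 2 to compound 3 (0.08 log units; within the scatter), within the scatter. The estimate for compound 3 is 30 nM, between 10 nM and 90 nM.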

Compound 3, half-maximal inhibitory concentration: 7 nM
For compound 3 the middle estimate is 4.3-fold (0.63 log units) above the measured one; measured number outside the range, below it.
By their numbers in this assay, from the lowest: compounds 3 and 1 (each within the scatter of the next); then compound 2.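

In this assay, pyridin-3-yl in place of pyridin-2-yl gives a 3.6-fold lower number from compound 2 to compound 3 (0.55 log units; beyond the scatter) on the same saturated ring carbon, so the place of the nitrogen within the pyridinyl ring matters here even though the counted atoms stay the same. The other new step, a 1.6-fold lower number from compound 1 to compound 3 (0.20 log units; within the scatter), lies within the scatter, so the rise seen with pyridin-2-yl does not extend to pyridin-3-yl. Nothing available explains this difference.

The compounds shown leave open how pyridin-4-yl or a phenyl ring bearing an amine would fare at this carbon. They also leave open whether the same preference for pyridin-3-yl holds when the rest of the shared core changes.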